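Swapping the aryl partner on a sulfonamide chemokine receptor antagonist

The source may report more compounds than this note shows. Statements on the series, on what has been measured and on what is new or still open speak of the compounds shown alone.

Among the measured compounds shown here, compound 1 `COc1cccnc1-c1cc(Cl)ccc1NS(=O)(=O)c1ccc(C(C)(C)C)cc1` is the weakest inhibitor of the three compounds measured so far in a functional assay on isolated protein for antagonist activity at C-C chemokine receptor type 9 (Homo sapiens), read by calcium flux, with a stated time of 10 min (a higher number here means a weaker inhibitor, a lower number a stronger inhibitor), where compound 1 gives 958 nM. Its nearest neighbour is compound 2 `CC(C)(C)c1ccc(S(=O)(=O)Nc2ccc(Cl)cc2-c2ncccc2CO)cc1`, which gives 89 nM; the change of hydroxymethyl in place of methoxy on an aromatic carbon brings an 11-fold lower number from compound 1 to compound 2 (1.03 log units; beyond the scatter). Furthest away is compound 3 `CC(C)(C)c1ccc(S(=O)(=O)Nc2ccc(Cl)cc2-c2ncncc2N)cc1`, which gives 3.2 nM, with a 300-fold lower number from compound 1 to compound 3 (2.48 log units; beyond the scatter) and, from the hydroxymethyl analogue, a 28-fold lower number from compound 2 to compound 3 (1.44 log units; beyond the scatter).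

Compound 4 `CC(C)(C)c1ccc(S(=O)(=O)Nc2ccc(Cl)cc2-c2nc(N)ncc2O)cc1` keeps the shared core and the sulfonamide of compound 1 but carries a different aryl partner: a group of 8 heavy atoms (4 carbon, 3 nitrogen, 1 oxygen; one six-membered aromatic ring with 2 hetero atoms) in place of a group of 8 heavy atoms (6 carbon, 1 nitrogen, 1 oxygen; one six-membered aromatic ring with 1 hetero atom), on an aromatic carbon. The entering group, like that of compound 3, is a six-membered aromatic ring with 2 hetero atoms bearing an amino group, and it also carries a hydroxyl, which recalls the hydroxymethyl of compound 2. Both steps from compound 1 therefore bear on this change, and both were large and in the same direction, so a large lowering of the number is expected for compound 4, likely between the steps to compound 2 and compound 3, amounting to a 64-fold lower number from compound 1 to compound 4 (1.81 log units; beyond the scatter). Compound 4 is thus estimated at 15 nM, with a range from 3 nM to 80 nM.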

Compound 4, half-maximal inhibitory concentration: 4 nM
For compound 4 the middle estimate is 3.8-fold (0.57 log units) above the measured one; the measured number falls inside the stated range.
By their numbers in this assay, from the lowest: compounds 3 and 4 (each within the scatter of the next); then compound 2; then compound 1.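

In this assay, the step of a 240-fold lower number from compound 1 to compound 4 (2.38 log units; beyond the scatter) shows that a second aryl partner built on a six-membered aromatic ring with 2 hetero atoms can also reach the low-nanomolar level at this aromatic carbon, so the result does not rest on compound 3 alone. The entering group of compound 4 carries a hydroxyl that compound 3 lacks and has its amino group placed differently, yet the change gives a 1.3-fold higher number from compound 3 to compound 4 (0.10 log units; within the scatter), so this position tolerates that rearrangement and the two partners cannot be told apart here. The step of a 22-fold lower number from compound 2 to compound 4 (1.35 log units; beyond the scatter) adds that an oxygen-bearing substituent does not account for the low number by itself, as compound 2 has a hydroxymethyl group and stays well short of compound 4.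

No measurement offered here explains why these partners outperform the 3-methoxypyridin-2-yl group of compound 1. Both partners at this level carry an amine as well as the second ring hetero atom, so the shares of the two remain unseparated, and the same ring bearing a methyl group or a methoxy group in place of the amine would bear on that question.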